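Shortening the sulfonyl aryl substituent in a sulfonamide series

A few compounds are considered here, and "the series" means these few. Any claim that something is new, unique, unknown or untested is made for them only; others in the source may bear on it.

Three related sulfonamides have numbers in a functional assay on MIA PaCa-2 cells (Homo sapiens) for inhibition, read by MTT assay, with a stated time of 72 h; on this read-out lower numbers stand for stronger inhibition of growth and higher numbers for weaker inhibition of growth. Compound 1 `CC(C)(C)c1ccc(CNCCNS(=O)(=O)c2cc(C(F)(F)F)cc(C(F)(F)F)c2)cc1` gives 15000 nM, compound 2 `CCCCc1ccc(S(=O)(=O)NCCCCCCNCc2ccc(Br)cc2)cc1` gives 5700 nM, and compound 3 `O=S(=O)(NCCCNCc1ccc(C(F)(F)F)cc1)c1cc(C(F)(F)F)cc(C(F)(F)F)c1` gives 2500 nM. Compound 2 thus stands second highest of the three, beyond the scatter from compound 3 on one side and from compound 1 on the other. Compound 4 `O=S(=O)(NCCCCCCNCc1ccc(Br)cc1)c1ccc(Cl)cc1` has not yet been tested; it differs from compound 2 by chloro in place of butyl on an aromatic carbon. For the measured compounds named here, no step of this kind has been measured here, so the direction must be judged with caution. Only a modest step is expected, if any, leaning toward weaker growth inhibition, with a 1.3-fold higher number from compound 2 to compound 4 (0.12 log units; within the scatter) as the estimated shift. Compound 4 is therefore expected to give 7500 nM, within 3000 nM to 20000 nM.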

Compound 4, concentration for 50% growth inhibition: 5900 nM
Compound 4: the middle estimate sits 1.3-fold (0.10 log units) above what was measured, within the range that was stated.
By their numbers in this assay, from the lowest: compound 3; then compounds 2 and 4 (each within the scatter of the next); then compound 1.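

The step of a 1.0-fold higher number from compound 2 to compound 4 (0.01 log units; within the scatter) shows that in this assay this aromatic carbon, para to a large group, tolerates the exchange of butyl for chloro with no shift beyond the scatter. For the compounds shown here, the earlier compounds offered no single-place comparison, so this is the first reading of this position, and here a four-carbon chain and a single chlorine read alike. No measurement available here offers an explanation for this result.

As far as these compounds go, whether an amine, a carboxylic acid or a longer chain on this carbon would also read alike remains open. So does whether chloro and butyl would match on another core.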